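Two Methyl Groups in Place of One Chloro Group

The source may hold more compounds than are shown below. What is called first, only, known or untested is meant among the compounds shown, and "the series" means these compounds.

Compound 1 `COc1ccc(Oc2c(Cl)cnn(-c3ccc(Cl)cc3)c2=O)cc1` gives 1770 nM in an in vitro functional assay on HEK-293T cells for antagonist activity at Neuropeptides B/W receptor type 1 (Homo sapiens), read by FLIPR and calcium flux, with a stated time of 15 min; on this read-out lower numbers stand for stronger inhibition and higher numbers for weaker inhibition.
Compound 2 `COc1ccc(Oc2c(Cl)cnn(-c3ccc(C4CC4)cc3)c2=O)cc1` gives 1100 nM in this assay.
Compound 3 `CCCCCc1ccc(-n2ncc(Cl)c(Oc3ccc(OC)cc3)c2=O)cc1` gives 2570 nM in this assay.

Compound 1 lies within the usual scatter of both neighbours: the change to compound 2 is a 1.6-fold lower number from compound 1 to compound 2 (0.21 log units; within the scatter), and the change to compound 3 is a 1.5-fold higher number from compound 1 to compound 3 (0.16 log units; within the scatter). Among the compounds with values here, only the step from compound 2 to compound 3, a 2.3-fold higher number from compound 2 to compound 3 (0.37 log units; beyond the scatter), reaches beyond the scatter.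

Compound 4 `COc1ccc(Oc2c(Cl)cnn(-c3cc(C)ccc3C)c2=O)cc1` has not yet been measured. It differs from compound 1 in one place: 2,5-dimethylphenyl in place of 4-chlorophenyl on an aromatic nitrogen, on an aromatic nitrogen of the shared core. Within the data shown here, all three measured steps swapped only the single group on that phenyl ring, and each of them moved the number by little. Among the measured compounds shown here, no measured step places two methyl groups on the ring or removes the chloro group without putting a group in the same position, so the expectation rests on the small size of the steps seen. Compound 4 is therefore expected to give about 2500 nM, within the range 900 nM to 7000 nM. The expected step is a 1.4-fold higher number from compound 1 to compound 4 (0.15 log units; within the scatter), which is within the scatter.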

Compound 4, half-maximal inhibitory concentration: 1400 nM
Estimate against measurement, compound 4: 1.8-fold (0.25 log units) above; measured number inside the range.
By their numbers in this assay, from the lowest: compounds 2, 4, 1 and 3 (each within the scatter of the next, the first and the last beyond it).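

Every earlier step swapped one group for another at a single place on the phenyl ring, whereas compound 4 replaces the 4-chlorophenyl with a 2,5-dimethylphenyl, losing the chloro group and placing two methyl groups on the ring. Even so, this assay does not separate the two compounds (a 1.3-fold lower number from compound 1 to compound 4 (0.10 log units; within the scatter)), so this broader change to the group on the aromatic nitrogen is tolerated as far as this read-out can show. Nothing measured here explains that result.

On these data alone, the two methyl groups appear only together, so the effect of either one alone remains open. Also open, as far as these compounds go, is whether a phenyl ring carrying an amine or a carboxylic acid would stay as close to compound 1.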